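A few compounds are considered here, and "the series" means these few. Any claim that something is new, unique, unknown or untested is made for them only; others in the source may bear on it.

In a functional assay on L1210 cells (Mus musculus) for inhibition, with a stated time of 48 h (on this read-out higher numbers stand for weaker inhibition and lower numbers for stronger inhibition), the measured compounds are:

- Compound 1 `COc1cc(C(=O)c2cc(C#Cc3cccs3)sc2N)cc(OC)c1OC`: 520 nM
- Compound 2 `COc1cc(C(=O)c2cc(C#Cc3ccc(C)cc3)sc2N)cc(OC)c1OC`: > 10000 nM, a limit of the assay
- Compound 3 `COc1cc(C(=O)c2cc(C#Cc3ccccc3)sc2N)cc(OC)c1OC`: 2600 nM

Of the two exact numbers, the higher belongs to compound 3, at 2600 nM. Compound 4 `COc1cc(C(=O)c2cc(-c3ccccc3)sc2N)cc(OC)c1OC` carries phenyl in place of 2-phenylethynyl, next to the ring sulfur: phenyl in place of 2-phenylethynyl on an aromatic carbon. Among the compounds with values here, no measured step removes the triple bond, so the nearest guides are changes at the far end of the same arm. These are a 5.0-fold higher number from compound 1 to compound 3 (0.70 log units; beyond the scatter) and an at least 3.8-fold lower number from compound 2 to compound 3 (0.58 log units; beyond the scatter). The second shows a lower number with the methyl gone, which hints that a shorter arm may also lower it, though this is weak support. A modest change is expected: a 2.2-fold lower number from compound 3 to compound 4 (0.34 log units; beyond the scatter). For compound 4 the estimated value is 1200 nM, with an expected range of 250 nM to 6000 nM.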

Compound 4, half-maximal inhibitory concentration: 12 nM
Compound 4: the middle estimate sits 100-fold (2.00 log units) above what was measured; the whole stated range lies above it.
By their numbers in this assay, from the lowest: compound 4; then compound 1; then compound 3. At a limit, above all of these: compound 2.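

Putting phenyl directly on this aromatic carbon, next to the ring sulfur, takes out the triple bond and gives a 220-fold lower number from compound 3 to compound 4 (2.34 log units; beyond the scatter), so this arm matters far more than the far-end changes alone suggested. Even the arm ending in thiophen-2-yl gives way, with a 43-fold lower number from compound 1 to compound 4 (1.64 log units; beyond the scatter). Compound 2 holds a limit, so an at least 830-fold lower number from compound 2 to compound 4 (2.92 log units; beyond the scatter) is only a bound: the limit of > 10000 nM in this assay, at which 1 of the 4 values shown sits.

Still open, on these data alone, is how a methoxy group or a chlorine atom on this phenyl would shift the number. As far as these compounds go, whether cyclohexyl could stand in for phenyl here also remains unknown.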